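This account rests on a few compounds, and the source may have more. Where it says the series, first, only, none or still open, it means among the compounds named here.

Measured compounds:

- compound 1, `COc1ccc(C2Cc3nccn3C2)cc1`: in an in vitro ADME assay on microsomes from liver (Homo sapiens) for metabolic stability (on this read-out lower numbers stand for slow clearance and higher numbers for fast clearance), compound 1 gives 30 mL.min-1.g-1
- compound 2, `Clc1ccc(C2Cc3nccn3C2)cc1`: in this assay compound 2 gives 32 mL.min-1.g-1
- compound 3, `COc1ccccc1C1Cc2nccn2C1`: in this assay compound 3 gives 37 mL.min-1.g-1

Compound 4, `Clc1ccccc1C1Cc2nccn2C1`, has not yet been measured in this assay.

Compounds 1 and 2 share one core and differ in a single spot: chloro in place of methoxy on an aromatic carbon. That change gave a 1.1-fold higher number from compound 1 to compound 2 (0.03 log units; within the scatter), so the two numbers are as good as the same.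

Compound 3 is built from the same atoms as compound 1, joined differently; how the two cores differ is not broken down here. Its value in this assay sits with those of compounds 1 and 2, all three within the usual scatter of one another.

From compound 3 to compound 4 the change is chloro in place of methoxy on an aromatic carbon. The group that leaves and the group that enters are the same as in the step from compound 1 to compound 2, but the place differs: in compound 1 the spot is para to a group of 8 heavy atoms, in compound 3 it is ortho to a group of 8 heavy atoms. It is therefore the same kind of change, not the same change.

Given that compound 1 to compound 2 showed a 1.1-fold higher number from compound 1 to compound 2 (0.03 log units; within the scatter), compound 4 is expected to land close to compound 3, with an expected step of a 1.1-fold higher number from compound 3 to compound 4 (0.03 log units; within the scatter). The estimate for compound 4 in this assay is 40 mL.min-1.g-1, expected to fall between 25 mL.min-1.g-1 and 65 mL.min-1.g-1.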

Compound 4, intrinsic clearance in microsomes: 18 mL.min-1.g-1
Estimate against measurement, compound 4: 2.2-fold (0.35 log units) above; measured number outside the range, below it.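

In this assay putting chloro in place of methoxy on the core of compound 3 gave a 2.1-fold lower number from compound 3 to compound 4 (0.31 log units; beyond the scatter) and so counts as a modest step, large enough to stand out from the ordinary spread of repeat measurements. Yet setting this step beside the earlier one does not establish that the two cores respond differently, since the gap between the steps is no larger than two such steps can show by chance: the same change on two cores in this assay, a 1.1-fold higher number (0.03 log units; within the scatter) from compound 1 to compound 2 and a 2.1-fold lower number (0.31 log units; beyond the scatter) from compound 3 to compound 4, 2.2-fold (0.34 log units) apart, within the scatter of two such steps. Within the data shown here, with only one pair on each core, this neither proves that the change carries over unchanged from one core to the other nor shows that the outcome depends on the core, and it gives no reason why the number fell from compound 3 to compound 4.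

The compounds shown leave open how groups other than methoxy and chloro, such as fluoro, a nitrile or an amine, would read when placed ortho to a group of 8 heavy atoms on this six-membered aromatic ring. They also leave open whether a further pair with the same swap on another core would side with the small step or the larger one.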